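The source may report more compounds than this note shows. Statements on the series, on what has been measured and on what is new or still open speak of the compounds shown alone.

In a functional assay on MGC-803 cells (Homo sapiens) for antiproliferative activity, read by MTT assay, with a stated time of 72 h (on this read-out higher numbers stand for weaker inhibition and lower numbers for stronger inhibition), compound 1 `CCCSc1nc(Cl)c2c(n1)N(Cc1cccs1)C(C(=O)N1CCN(C)CC1)N2` gives 62300 nM. Compound 2 `CCCSc1nc(Cl)c2c(n1)N(Cc1ccccc1)C(C(=O)N1CCN(C)CC1)N2` differs from it in one place, phenyl in place of thiophen-2-yl on a saturated chain carbon bound to a nitrogen on an aromatic ring in a ring. In this assay compound 2 reaches only > 64000 nM, which is a limit of the assay and not a number. The step of an at least 1.0-fold higher number from compound 1 to compound 2 (0.01 log units; that floor lies within the scatter) is therefore only a floor, because compound 2 sits at the limit of > 64000 nM in this assay, at which 1 of the 2 values shown sits. Compound 3 `CCCSc1nc(Cl)c2c(n1)N(Cc1ccccc1)C(C(=O)NCC(C)C)N2` keeps the phenyl group and changes the amide end: isobutylamino in place of 4-methylpiperazin-1-yl on a carbonyl carbon. Going by the values given here, no measured step touches the carbonyl carbon, so none of the measured steps bears on this change. Compound 2 stands at the limit, and compound 3 is expected to remain weak, the estimated step that the limit leaves unreadable from compound 2 to compound 3 meaning nothing beyond the scatter. Compound 3 is estimated at 70000 nM, with a range from 25000 nM to 200000 nM.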

Compound 3, half-maximal inhibitory concentration: 58400 nM
The estimate for compound 3 lay 1.2-fold (0.08 log units) above the measured number; the measured number falls inside the stated range.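

With isobutylamino in place of 4-methylpiperazin-1-yl on a carbonyl carbon, a compound carrying the phenyl group now gives a number in this assay: compound 3 reaches 58400 nM. Going by these compounds alone, compound 2 stands at a limit of the assay and not at a number: the limit of > 64000 nM in this assay, at which 1 of the 3 values shown sits. The only reading is an at least 1.0-fold lower number from compound 2 to compound 3 (0.03 log units; that floor lies within the scatter), so replacing the six-membered ring with an open chain that brings a hydrogen-bond donor shows no change beyond the scatter at this position.

The compounds shown leave open whether any group on this carbonyl carbon moves the number, such as morpholin-4-yl, a primary amine on a longer chain or a carboxylic acid. They also leave open how thiophen-2-yl in place of phenyl would read alongside isobutylamino.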